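The compounds below may be only part of what the source reports. "The series", "measured", "known", "first", "only" and "open" are said of these compounds alone.

In a functional assay on HCT-15 cells (Homo sapiens) for cytotoxicity, read by ELISA, with a stated time of 4 days (on this read-out lower numbers stand for stronger inhibition and higher numbers for weaker inhibition), compound 1 (`Cc1ccc(-c2cc(-c3ccoc3)cc(-c3ccc(Cl)s3)n2)o1`) gives 790 nM and compound 2 (`Clc1ccc(-c2cc(-c3ccoc3)cc(-c3ccccn3)n2)s1`) gives 1270 nM, and these two values lie within the scatter of each other. Compound 3 (`Clc1ccc(-c2cc(-c3ccoc3)cc(-c3cccnc3)n2)s1`) differs from compound 2 in one place: pyridin-3-yl in place of pyridin-2-yl on an aromatic carbon. Among the compounds with values here, the one measured step that bears on this change is a 1.6-fold higher number from compound 1 to compound 2 (0.21 log units; within the scatter), made at the same place. On that evidence, no step beyond the scatter is expected in this assay, in either direction. The estimated change is a 1.1-fold lower number from compound 2 to compound 3 (0.02 log units; within the scatter). Compound 3 is expected at 1200 nM, within an estimated range of 500 nM to 2900 nM.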

Compound 3, half-maximal inhibitory concentration: 720 nM
For compound 3 the middle estimate is 1.7-fold (0.22 log units) above the measured one, and the stated range covers the measured number.
By their numbers in this assay, from the lowest: compounds 3, 1 and 2 (each within the scatter of the next).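

In this assay, pyridin-3-yl in place of pyridin-2-yl gives a 1.8-fold lower number from compound 2 to compound 3 (0.25 log units; within the scatter) and pyridin-3-yl in place of 5-methylfuran-2-yl gives a 1.1-fold lower number from compound 1 to compound 3 (0.04 log units; within the scatter) at the same aromatic carbon. Within the data shown here, the place of the nitrogen in the pyridine ring, tested here for the first time, therefore makes no difference beyond the scatter, and the three groups at this position cannot be told apart. Nothing measured here explains the result.

The compounds shown leave open whether pyridin-4-yl would behave likewise. They also leave open whether an amine or a carboxylic acid at this position would give a step beyond the scatter.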